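The source may report more compounds than this note shows. Statements on the series, on what has been measured and on what is new or still open speak of the compounds shown alone.

Compound 1 `Cc1nc(NC(=O)c2ccccc2)sc1C(=O)/C=C/c1ccc(Br)cc1` stands second highest among the three compounds measured in an assay for inhibition of Polyunsaturated fatty acid 5-lipoxygenase (Homo sapiens), read by spectrophotometry, tested at 10 uM, in the presence of a further agent that is not named here (a higher number here means more inhibition at the concentration tested (going by the name of the read-out), a lower number less inhibition), where compound 1 gives 52.3%. Compound 2 `Cc1nc(NC(=O)c2ccc([N+](=O)[O-])cc2)sc1C(=O)/C=C/c1ccc(Cl)cc1` gives 48.8%, a number within the scatter of that of compound 1, while compound 3 `COc1ccc(/C=C/C(=O)c2sc(NC(=O)c3ccccc3)nc2C)cc1OC` gives 70.2%, a number beyond the scatter and higher than that of compound 1. Compound 4 `Cc1nc(NC(=O)c2ccccc2)sc1C(=O)/C=C/c1ccco1` has not yet been measured; it differs from compound 1 by furan-2-yl in place of 4-bromophenyl on a double-bonded chain carbon bound to a double-bonded chain carbon. Within the data shown here, no two measured compounds differ in a single place, so no measured step guides this change. In this assay the expected step is a number 5.3 percentage points lower from compound 1 to compound 4 (within the scatter), most likely not beyond the scatter. Compound 4 is therefore estimated to give 47% in this assay, within a range from 28% to 66%.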

Compound 4, a percentage reported as inhibition, at one concentration (the size of the read-out at that concentration, not a potency): 57.2%
Compound 4: the middle estimate sits 10.2 percentage points below what was measured, within the range that was stated.
By their numbers in this assay, from the lowest: compounds 2, 1 and 4 (each within the scatter of the next); then compound 3.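

In this assay, furan-2-yl in place of 4-bromophenyl gives a number 4.9 percentage points higher from compound 1 to compound 4 (within the scatter), the first single-place step read at this position. It shows that a six-membered aromatic ring of carbon only can give way here to a smaller five-membered aromatic ring with a hetero atom, with no change beyond the scatter. No measurement at hand bears on why the number holds at this position. As far as these compounds go, what an amine or a carboxylic acid at this place would give remains open.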